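Moving the Pyridine Nitrogen in Two Related Series

The source may report more compounds than this note shows. Statements on the series, on what has been measured and on what is new or still open speak of the compounds shown alone.

Compound 1 `C[C@@H](NC(=O)[C@H](CCCNC(=N)N)NC(=O)c1ccc(CN(Cc2ccc(F)cc2)Cc2cccnc2)cc1)c1cccc2ccccc12` and compound 2 `C[C@@H](NC(=O)[C@H](CCCNC(=N)N)NC(=O)c1ccc(CN(Cc2ccncc2)Cc2ccc(F)cc2)cc1)c1cccc2ccccc12` share one core, while compound 3 `C[C@H](NC(=O)[C@H](CCCNC(=N)N)NC(=O)c1ccc(CN(Cc2cccnc2)C(=O)c2ccc(F)cc2)cc1)c1cccc2ccccc12` and compound 4 `C[C@H](NC(=O)[C@H](CCCNC(=N)N)NC(=O)c1ccc(CN(Cc2ccncc2)C(=O)c2ccc(F)cc2)cc1)c1cccc2ccccc12` share another; the difference between the two cores is not broken down here. In an assay on Jurkat cells for displacement of a labelled ligand from C-X-C chemokine receptor type 4 (Homo sapiens), tested at 10 uM (on this read-out higher numbers stand for more inhibition at the one concentration tested (going by the name of the read-out) and lower numbers for less inhibition), compound 1 gives 6% and compound 2 gives 12%. Compound 3 gives 14% in this assay. The change from compound 1 to compound 2 is pyridin-4-yl in place of pyridin-3-yl on a saturated chain carbon bound to an amine nitrogen, and it made a number 6 percentage points higher from compound 1 to compound 2 (within the scatter). The change from compound 3 to compound 4 is pyridin-4-yl in place of pyridin-3-yl on a saturated chain carbon bound to an amide-type nitrogen; it is the same kind of change, but here the saturated chain carbon is bound to an amide-type nitrogen rather than to an amine nitrogen. Compound 4 has not yet been measured in this assay. The step expected in this case is a number 4 percentage points higher from compound 3 to compound 4 (within the scatter), an estimate that rests on the observation that a number 6 percentage points higher from compound 1 to compound 2 (within the scatter) lies within the scatter, with no other guide available. On that basis compound 4 is estimated at 18%, with an expected range from 5% to 32%.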

Compound 4, a percentage reported as inhibition, at one concentration (the size of the read-out at that concentration, not a potency): 13%
For compound 4 the middle estimate is 5 percentage points above the measured one; the range from low to high includes it.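

In this assay, pyridin-4-yl in place of pyridin-3-yl on the core of compound 3 gave a number 1 percentage points lower from compound 3 to compound 4 (within the scatter), and the same change on the two cores does not differ beyond what repeated measurements would allow: the same change on two cores in this assay, a number 6 percentage points higher (within the scatter) from compound 1 to compound 2 and a number 1 percentage points lower (within the scatter) from compound 3 to compound 4, 7 percentage points apart, within the scatter of two such steps

The change therefore carries from the core with the amine nitrogen to the core with the amide-type nitrogen without a step on either core that stands clear of the scatter. This does not show that the step is the same size on both cores, or that it is zero on either, and a reading at one concentration gives no potency.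

The compounds shown leave open what pyridin-2-yl or a plain phenyl ring would do in the same place on either core. They also leave open how the two cores compare one change at a time, since they differ in more than one place.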